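From Bromo to Chloro: A Stability Estimate

The source may report more compounds than this note shows. Statements on the series, on what has been measured and on what is new or still open speak of the compounds shown alone.

A compound that a drug is built from must survive long enough in the body, and liver microsomes offer a simple early test of this. In an ADME assay on microsomes from liver (Mus musculus, strain CD-1) for metabolic stability (a lower number here means that the compound disappears faster, a higher number that the compound lasts longer), compound 1 `COc1ccc(C(=O)Nc2nc(-c3ccccn3)cs2)cc1` gives 0.267 h. Compound 2 `O=C(Nc1nc(-c2ccccn2)cs1)c1cccc(Br)c1` gives 0.183 h in this assay. Among the measured compounds shown here, these two values lie within the usual scatter of each other, so compound 2 stands level with compound 1 on the numbers so far.

The next molecule, compound 3 `O=C(Nc1nc(-c2ccccn2)cs1)c1cccc(Cl)c1`, differs from compound 2 in one place: chloro in place of bromo on an aromatic carbon. This is chloro in place of bromo on an aromatic carbon, turning 3-bromophenyl into 3-chlorophenyl. For the measured compounds named here, no pair of measured compounds differs in only one place, so the data offer no direct guide to the size of such a step in this assay. With so little to go on, no change beyond the scatter is expected, in either direction. The expected change is a 1.1-fold higher number from compound 2 to compound 3 (0.04 log units; within the scatter), which stays within the scatter. For compound 3 the estimated half-life is 0.2 h, with an expected range from 0.11 h to 0.36 h.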

Compound 3, half-life: 0.317 h
Estimate against measurement, compound 3: 1.6-fold (0.20 log units) below; the range from low to high includes it.
By their numbers in this assay, from the lowest: compounds 2, 1 and 3 (each within the scatter of the next).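

Chloro in place of bromo on an aromatic carbon gives a 1.7-fold higher number from compound 2 to compound 3 (0.24 log units; within the scatter) in this assay, the first single-place step in this small series. At this position of the six-membered aromatic ring, going from 3-bromophenyl to 3-chlorophenyl therefore leaves the half-life indistinguishable from that of the bromo compound, since a gap of this size is no larger than repeat measurements of a single compound can show, and the pair offers no reason to prefer one group over the other on this read-out alone. No measured evidence is available to explain this outcome, and a single pair cannot supply any.

Among the compounds shown here, this one step covers only two groups at one place on the ring, so it remains open whether an amine, a carboxylic acid or a longer chain on the same aromatic carbon would give a step beyond the scatter. Going by these compounds, it also remains open whether chloro in place of bromo would give a similar step elsewhere on the ring or on a different core.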